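Hydroxy in Place of Fluoro: Toward Compound 3

This account rests on a few compounds, and the source may have more. Where it says the series, first, only, none or still open, it means among the compounds named here.

Compound 1 `CN(C)C(=O)c1cc2cnc(Nc3ccc(C(=O)NCCCCCN=C=S)cc3F)nc2n1C1CCCC1` gives 15.6% in a functional assay on A549 cells (Homo sapiens) for inhibition, read by CCK-8 assay, with a stated time of 72 h, tested at 10 uM; on this read-out higher numbers stand for a stronger effect at the one concentration tested and lower numbers for a weaker effect. Among the compounds with values here, its only measured neighbour, compound 2 `CN(C)C(=O)c1cc2cnc(Nc3ccc(C(=O)NCCCCCCN=C=S)cc3F)nc2n1C1CCCC1`, gives 22.9%, and the step of a number 7.3 percentage points higher from compound 1 to compound 2 (within the scatter) concerns the saturated chain, not the aromatic ring. Compound 3 `CN(C)C(=O)c1cc2cnc(Nc3ccc(C(=O)NCCCCCN=C=S)cc3O)nc2n1C1CCCC1` differs from compound 1 by hydroxy in place of fluoro on an aromatic carbon. Within the data shown here, no measured step touches this position, so nothing in hand sets the size or direction of the change. The step is expected to be a number 0.4 percentage points higher from compound 1 to compound 3 (within the scatter). Compound 3 is therefore estimated at 16%, within 4% to 32%, with the range kept wide.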

Compound 3, a percentage reported as inhibition, at one concentration (the size of the read-out at that concentration, not a potency): 30.7%
Compound 3: the middle estimate sits 14.7 percentage points below what was measured; the range from low to high includes it.
By their numbers in this assay, from the lowest: compounds 1, 2 and 3 (each within the scatter of the next, the first and the last beyond it).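

Within the data shown here, at this aromatic carbon, which no earlier step touched, hydroxy in place of fluoro gives a number 15.1 percentage points higher from compound 1 to compound 3 (beyond the scatter) in this assay, so the position responds to this exchange. Hydroxy brings a hydrogen-bond donor and a hydrogen-bond acceptor where fluoro counts neither, but nothing at hand shows what lies behind the step.

As far as these compounds go, whether an amine or a methoxy group on the same carbon would match hydroxy remains open. So does whether the exchange would give a similar step on the longer chain of compound 2.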